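Fluoro replaces methyl on the pendant phenyl ring

The source may report more compounds than this note shows. Statements on the series, on what has been measured and on what is new or still open speak of the compounds shown alone.

Compound 3 `COc1cc2c(Oc3ccc(NC(=O)c4cc(-c5ccccc5C)ccn4)cc3F)ccnc2cc1OCCCN1CCCC1` gives the highest number among the three measured compounds in a functional assay on NCI-H460 cells (Homo sapiens) for cytotoxicity, read by MTT assay, with a stated time of 72 h (a lower number here means a stronger inhibitor, a higher number a weaker inhibitor), with a half-maximal inhibitory concentration of 420 nM. Within the data shown here, compound 2 `COc1cc2c(Oc3ccc(NC(=O)c4cc(-c5ccccc5)ccn4)cc3F)ccnc2cc1OCCCN1CCCC1` carries hydrogen where compound 3 carries methyl; in this assay compound 2 gives 130 nM, and the step of a 3.2-fold higher number from compound 2 to compound 3 (0.51 log units; beyond the scatter) is the only measured step that bears directly on substitution at this carbon. Compound 1 `COc1cc2c(Oc3ccc(NC(=O)c4cc(-c5ccccc5F)ccn4)cc3F)ccnc2cc1OCCCN1CCN(C)CC1`, which carries fluoro on that carbon but a different amine at the end of the propoxy chain, gives 140 nM, a number close to that of compound 2. Compound 4 `COc1cc2c(Oc3ccc(NC(=O)c4cc(-c5ccccc5F)ccn4)cc3F)ccnc2cc1OCCCN1CCCC1` differs from compound 3 by fluoro in place of methyl on an aromatic carbon. Since compound 3 and compound 2 differ by the step of a 3.2-fold higher number from compound 2 to compound 3 (0.51 log units; beyond the scatter), and since compound 1 with fluoro gives 140 nM, the change is expected to bring the number back down, so that the step from compound 3 to compound 4 is estimated at a 2.8-fold lower number from compound 3 to compound 4 (0.45 log units; beyond the scatter). Compound 4 is therefore expected to give about 150 nM in this assay, within a range of 70 nM to 350 nM.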

Compound 4, half-maximal inhibitory concentration: 140 nM
The estimate for compound 4 lay 1.1-fold (0.03 log units) above the measured number; the measured number falls inside the stated range.
By their numbers in this assay, from the lowest: compounds 2, 1 and 4 (each within the scatter of the next); then compound 3.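

In this assay the step of a 3.0-fold lower number from compound 3 to compound 4 (0.48 log units; beyond the scatter) shows that fluoro undoes what methyl did to the number, and the step of a 1.1-fold higher number from compound 2 to compound 4 (0.03 log units; within the scatter) sets fluoro level with hydrogen on this carbon, so that among these three groups only methyl stands apart. The step of no change at the digits printed from compound 1 to compound 4 (within the scatter) adds what compound 1 alone could not show: with the 2-fluorophenyl group held fixed, pyrrolidin-1-yl and 4-methylpiperazin-1-yl on the chain cannot be told apart in this assay.

On these data alone, whether chloro, methoxy or trifluoromethyl on this carbon would follow methyl or fluoro stays open, as does whether the two amines also match when the phenyl ring carries hydrogen or methyl. Nothing given here offers any explanation for why methyl stands apart from fluoro and hydrogen.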